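A Thiocarbamate Series Held at the Cytotoxicity Ceiling

The compounds below may be only part of what the source reports. "The series", "measured", "known", "first", "only" and "open" are said of these compounds alone.

Compound 1, `Cc1ccc(NC(=S)OCCNC(=O)C(C)(C)Oc2ccc(Cl)cc2)cc1`: > 800000 nM
Compound 2, `O=C(Oc1ccc(-c2cc(=S)ss2)cc1)c1cccnc1`: > 800000 nM
Compound 3, `CC(C)(Oc1ccc(Cl)cc1)C(=O)Oc1ccc(C(N)=S)cc1`: > 800000 nM

The study measures an ADME assay on RAW264.7 cells (Mus musculus) for cytotoxicity, read by MTT assay, with a stated time of 48 h (a higher number here means a weaker inhibitor, a lower number a stronger inhibitor), for three compounds, none of which gives a number. Compound 1 reaches only > 800000 nM in this assay, which is a limit of the assay rather than a value. Compound 2 likewise stops at > 800000 nM, a limit. Compound 3 also sits at > 800000 nM, again a limit. Within the data shown here, all three share the same position, since the limit of > 800000 nM in this assay, at which 3 of the 3 values shown sit: nothing in the set separates one compound from another, and no step between measured compounds can be read.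

The next compound, compound 4, `CC(C)(Oc1ccc(Cl)cc1)C(=O)NCCOC(=S)Nc1ccc([N+](=O)[O-])cc1Cl`, differs from compound 1 in a single place: 2-chloro-4-nitrophenyl in place of 4-methylphenyl on an amide-type nitrogen. Among the measured compounds shown here, with no measured step to lean on, the only guide is that every compound so far rests at the same limit. The step from compound 1 to compound 4 is therefore expected to be none beyond the scatter, that is a number no higher from compound 1 to compound 4 (the limit leaves the size open). Compound 4 is expected to give about 800000 nM in this assay, with a likely range of 400000 nM to 1600000 nM, and most probably the assay will again report only a limit.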

Compound 4, half-maximal inhibitory concentration: > 800000 nM
Compound 4 was reported as a limit; the forecaster's own chance of this, stated with the estimate: 80%; the middle value sits exactly at the limit.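

In this assay compound 4 gives > 800000 nM as a limit of the assay and not a number. The step from compound 1 to compound 4 therefore cannot be read, since both compounds rest at the same limit: the limit of > 800000 nM in this assay, at which 4 of the 4 values shown sit. The compounds shown leave open how far any of them lies past that limit, and whether 2-chloro-4-nitrophenyl in place of 4-methylphenyl shifts the read-out at all.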